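The compounds below may be only part of what the source reports. "The series", "measured", "known", "first", "only" and "open" are said of these compounds alone.

Measured so far:
compound 1, `CC#CCn1c(N2CCC[C@@H](N)C2)cc(=O)n(Cc2cc(Br)cc(C(=O)OC)c2)c1=O`: > 100 nM
compound 2, `CC#CCn1c(N2CCC[C@@H](N)C2)cc(=O)n(Cc2cccc(C(=O)O)c2F)c1=O`: "not determined" (no result reported)
compound 3, `CC#CCn1c(N2CCC[C@@H](N)C2)cc(=O)n(Cc2ccc(Br)c(C(=O)O)c2)c1=O`: > 100 nM

Three compounds that share one core have been examined in an assay on isolated protein for inhibition of Dipeptidyl peptidase 9 (Homo sapiens), read by fluorescence, with stated times of 15 min and 20 min; on this read-out higher numbers stand for weaker inhibition and lower numbers for stronger inhibition. Compound 3 returns only a limit in this assay, namely > 100 nM. Compound 1 likewise returns a limit in this assay, > 100 nM. For compound 2 no result is reported in this assay, the entry reading "not determined" (no result reported). Among the measured compounds shown here, compound 3 therefore stands at the limit of > 100 nM in this assay, at which 2 of the 3 values shown sit, and since no pair of measured compounds differs in one place, no measured step is available from which a size could be read.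

Compound 4 `CC#CCn1c(N2CCC[C@@H](N)C2)cc(=O)n(Cc2cc(Br)cc(C(=O)O)c2)c1=O` has not yet been measured. Set against compound 3, the change is 3-bromo-5-carboxyphenyl in place of 4-bromo-3-carboxyphenyl on a saturated chain carbon bound to an aromatic nitrogen.

For the measured compounds named here, because compound 3 sits at the limit of > 100 nM in this assay, at which 2 of the 3 values shown sit, there is no measured step to scale the expectation. The step that the limit leaves unreadable from compound 3 to compound 4 is expected to be none beyond the scatter, with compound 4 most likely reported at the same limit. In this assay compound 4 is expected to give roughly 300 nM, within a range from 50 nM to 3000 nM.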

Compound 4, half-maximal inhibitory concentration: > 100 nM
Compound 4 ended at the assay's limit; the forecaster's own chance of this, stated with the estimate: 70%; the middle value does not contradict the limit.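

In this assay compound 4 gives > 100 nM, which is a limit. The steps to compound 4 from compound 1 and from compound 3 therefore cannot be read. The compounds shown leave open whether 3-bromo-5-carboxyphenyl in place of 4-bromo-3-carboxyphenyl changes inhibition at all.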